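Amide nitrogen: propyl to tert-butyl on the shared core

This account rests on a few compounds, and the source may have more. Where it says the series, first, only, none or still open, it means among the compounds named here.

Compound 1 `C=CC1=C(C(=O)NCCC)C(c2ccc(F)cc2)OC1` carries a propyl group on the amide nitrogen. In a functional assay on QGY7701 cells (Homo sapiens) for cytotoxicity, read by MTT assay, with a stated time of 24 h (a higher number here means a weaker inhibitor, a lower number a stronger inhibitor), compound 1 returns > 100000 nM, which is a limit of the assay and not a number (the limit of > 100000 nM in this assay, at which 1 of the 2 values shown sits). Within the data shown here, compound 2 `C=CC1=C(C(=O)NCCC)C(c2ccc(Cl)c(Cl)c2)OC1` is the only other measured member; in this assay compound 2 gives 31300 nM. Compound 3 `C=CC1=C(C(=O)NC(C)(C)C)C(c2ccc(F)cc2)OC1` differs from compound 1 by tert-butyl in place of propyl on an amide-type nitrogen. Among the measured compounds shown here, no measured step covers this change, so for compound 3 the expected step of a number no higher from compound 1 to compound 3 (the limit leaves the size open) is taken to stay within the usual scatter. In this assay compound 3 is estimated at 100000 nM, with a range from 30000 nM to 300000 nM, and another limit is likely.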

Compound 3, half-maximal inhibitory concentration: > 100000 nM
Compound 3: no number, only a limit; the forecaster's own chance of this, stated with the estimate: 60%; the middle value sits exactly at the limit.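

In this assay compound 3 gives > 100000 nM, a limit of the assay and not a number. Among these compounds, compound 1 also stands at a limit, so no step between compound 1 and compound 3 can be read. The compounds shown leave open whether tert-butyl in place of propyl on the amide-type nitrogen changes the result at all.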